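This account rests on a few compounds, and the source may have more. Where it says the series, first, only, none or still open, it means among the compounds named here.

Measured so far in a functional assay on PC-3 cells (Homo sapiens) for antiproliferative activity, read by MTT assay, with a stated time of 72 h; on this read-out higher numbers stand for weaker inhibition and lower numbers for stronger inhibition:
compound 1 `CCC/C=C/C(=O)Nc1cc2c(N3CCc4ccccc43)ncnc2cc1OC` gives 4240 nM
compound 2 `COc1cc2ncnc(N3CCc4ccccc43)c2cc1NC(=O)/C=C/CN1CCCC1` gives 2620 nM

Among the measured compounds shown here, compound 2 carries the lowest of the two numbers in this assay, yet its only neighbour, compound 1, sits a single step away, and that step, a 1.6-fold lower number from compound 1 to compound 2 (0.21 log units; within the scatter), lies within the scatter, so the two compounds cannot be told apart on this read-out.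

Compound 3 `COc1cc2ncnc(N3CCc4ccccc43)c2cc1NC(=O)/C=C/CN1CCCCC1` has not yet been measured. It differs from compound 2 in one place: piperidin-1-yl in place of pyrrolidin-1-yl on a saturated chain carbon bound to a double-bonded chain carbon. For the measured compounds named here, the only measured step at this same position is a 1.6-fold lower number from compound 1 to compound 2 (0.21 log units; within the scatter), in which ethyl was replaced by pyrrolidin-1-yl, and even that larger swap stayed within the scatter. Going by the values given here, the move from a five-membered to a six-membered ring at this position is smaller still, and no measured pair shows what it does. The expectation is therefore no step beyond the scatter in this assay, with the estimated step of a 1.0-fold lower number from compound 2 to compound 3 (0.02 log units; within the scatter) from compound 2 to compound 3. Compound 3 is expected to give about 2500 nM, with a likely range from 1000 nM to 6500 nM.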

Compound 3, half-maximal inhibitory concentration: 4180 nM
The estimate for compound 3 lay 1.7-fold (0.22 log units) below the measured number; low and high end bracket the measured number.
By their numbers in this assay, from the lowest: compounds 2, 3 and 1 (each within the scatter of the next).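

In this assay, putting piperidin-1-yl in place of pyrrolidin-1-yl gives a 1.6-fold higher number from compound 2 to compound 3 (0.20 log units; within the scatter), while putting piperidin-1-yl in place of ethyl gives a 1.0-fold lower number from compound 1 to compound 3 (0.01 log units; within the scatter). Three different groups have now been compared on this saturated chain carbon bound to a double-bonded chain carbon, and none of the listed steps between them leaves the scatter, so neither the five- or six-membered ring nor the swap between a ring and ethyl produces a difference that this read-out can resolve. No separate measurement is available that could explain this flat result.

Still open, as far as these compounds go, is whether any group on this carbon can produce a step beyond the scatter, for example morpholin-4-yl, which has an oxygen atom in its ring, or dimethylamino, an amine with no ring at all. From the compounds shown here alone, all three compounds also share one core and one methoxy group, so it remains unknown whether the same flat picture would hold if either of those parts were different.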